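The source may report more compounds than this note shows. Statements on the series, on what has been measured and on what is new or still open speak of the compounds shown alone.

Compound 3 `Cc1ccc(OCC(=O)N(Cc2cccs2)c2ncco2)cc1` is the most potent of the three measured compounds: in an assay on HEK293 cells for agonist activity at transient receptor potential cation channel subfamily M member 8 (Homo sapiens), read by fluorescence and calcium flux, with a stated time of 15 min (on this read-out higher numbers stand for an effect only at larger amounts of compound and lower numbers for an effect already at smaller amounts), compound 3 gives 0.3 nM, the lowest number of the set. Compound 1 `Cc1ccc(OCC(=O)N(CCO)Cc2cccs2)cc1` gives 900 nM, and compound 2 `Cc1ccc(OCC(=O)N(Cc2cccs2)c2nccs2)cc1` gives 2240 nM. Both lie far from compound 3: a 3000-fold lower number from compound 1 to compound 3 (3.48 log units; beyond the scatter) and a 7500-fold lower number from compound 2 to compound 3 (3.87 log units; beyond the scatter), whereas a 2.5-fold higher number from compound 1 to compound 2 (0.40 log units; beyond the scatter) is a much smaller shift. Compound 4 `Cc1ccc(OCC(=O)N(Cc2cccs2)c2cccnc2)cc1` differs from compound 3 in one place: pyridin-3-yl in place of 1,3-oxazol-2-yl on an amide-type nitrogen. Within the data shown here, the steps that bear on this change are the two leading into compound 3, since each swaps the group on the same amide-type nitrogen. They show that the 1,3-oxazol-2-yl group goes with the very low number of compound 3, and that even the closely related 1,3-thiazol-2-yl of compound 2 sits far higher. A move to a six-membered pyridin-3-yl is therefore expected to undo most of that gain. For compound 4 the expected step is a 1700-fold higher number from compound 3 to compound 4 (3.22 log units; beyond the scatter), a large rise. Compound 4 is estimated at 500 nM, with a range from 20 nM to 5000 nM.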

Compound 4, half-maximal effective concentration: 198 nM
For compound 4 the middle estimate is 2.5-fold (0.40 log units) above the measured one, within the range that was stated.
By their numbers in this assay, from the lowest: compound 3; then compound 4; then compound 1; then compound 2.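

In this assay, pyridin-3-yl on the amide-type nitrogen gives up most of the very low number that 1,3-oxazol-2-yl holds (a 660-fold higher number from compound 3 to compound 4 (2.82 log units; beyond the scatter)). Yet it still does better than the other two groups at this place, both with 1,3-thiazol-2-yl (an 11-fold lower number from compound 2 to compound 4 (1.05 log units; beyond the scatter)) and with 2-hydroxyethyl (a 4.5-fold lower number from compound 1 to compound 4 (0.66 log units; beyond the scatter)). Ring size alone therefore does not order these compounds, since the five-membered rings of compound 3 and compound 2 lie on either side of the six-membered ring of compound 4.

Going by these compounds, whether a phenyl ring or an imidazole ring at this place would come near compound 3 remains open. Nothing at hand explains why these groups differ so widely.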